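Replacing nitro with butyl in compound 2

This account rests on a few compounds, and the source may have more. Where it says the series, first, only, none or still open, it means among the compounds named here.

In an ADME assay on J774 cells (Mus musculus) for cytotoxicity, read by MTT assay, with a stated time of 48 h (a lower number here means a stronger inhibitor, a higher number a weaker inhibitor), compound 1 `O=C(N/N=C/c1ccc([N+](=O)[O-])o1)c1ccc(Cl)cc1` gives 57100 nM and compound 2 `O=C(N/N=C/c1ccc([N+](=O)[O-])o1)c1ccc([N+](=O)[O-])cc1` gives 79100 nM, two values within the usual scatter of each other. Compound 3 `CCCCc1ccc(C(=O)N/N=C/c2ccc([N+](=O)[O-])o2)cc1` keeps the shared core of compound 2 but carries butyl in place of nitro on an aromatic carbon, para to a large group: butyl in place of nitro on an aromatic carbon. Within the data shown here, only one measured step bears on this change, a 1.4-fold higher number from compound 1 to compound 2 (0.14 log units; within the scatter), where nitro took the place of chloro. Among the measured compounds shown here, that step stayed within the scatter, but it is a single step and no butyl compound has been measured, so it offers only weak guidance. No large change is therefore expected, and the estimated step is a 1.4-fold lower number from compound 2 to compound 3 (0.16 log units; within the scatter). The estimate for compound 3 is 55000 nM, with an expected range from 20000 nM to 130000 nM.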

Compound 3, half-maximal inhibitory concentration: 28100 nM
The estimate for compound 3 lay 2.0-fold (0.29 log units) above the measured number; measured number inside the range.
By their numbers in this assay, from the lowest: compound 3; then compounds 1 and 2 (each within the scatter of the next).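

In this assay the group on this aromatic carbon turns out to matter: nitro and chloro gave values within the scatter of each other, but butyl brings a 2.8-fold lower number from compound 2 to compound 3 (0.45 log units; beyond the scatter) and a 2.0-fold lower number from compound 1 to compound 3 (0.31 log units; beyond the scatter) and so stands apart from both. These steps are modest, yet both lie beyond the scatter, which makes compound 3 the strongest inhibitor of the three in this assay. Nothing available here accounts for this shift.

As far as these compounds go, it remains open whether the shift belongs to butyl in particular or would also appear with a shorter chain such as methyl, a longer chain such as hexyl, or an amine at the same place. Three compounds in one assay also cannot show whether the number keeps falling as the chain grows.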